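Moving the Pyridine Nitrogen from Compound 2 to Compound 3

This account rests on a few compounds, and the source may have more. Where it says the series, first, only, none or still open, it means among the compounds named here.

Compound 1 `COc1ccc(C(=O)/C=C/c2cn(-c3ccccc3)nc2-c2cccnc2)cc1OC` — 4300 nM
Compound 2 `COc1ccc(OC)c(C(=O)/C=C/c2cn(-c3ccccc3)nc2-c2cccnc2)c1` — 1000 nM

In a functional assay on HCT-116 cells (Homo sapiens) for inhibition, read by sulforhodamine B assay, with a stated time of 72 h (a lower number here means a stronger inhibitor, a higher number a weaker inhibitor), compound 1 gives 4300 nM and compound 2 gives 1000 nM. Among the compounds with values here, compound 2 holds the lowest number of the two measured compounds; the single measured step, a 4.3-fold lower number from compound 1 to compound 2 (0.63 log units; beyond the scatter), concerns the aryl group on the carbonyl carbon. Compound 3 `COc1ccc(OC)c(C(=O)/C=C/c2cn(-c3ccccc3)nc2-c2ccncc2)c1` differs from compound 2 by pyridin-4-yl in place of pyridin-3-yl on an aromatic carbon. Within the data shown here, no measured step touches this position, so nothing here speaks for a shift beyond the scatter in this assay. Compound 3 is therefore expected to show 1000 nM, with a range from 400 nM to 2500 nM. The expected step is no change at the digits printed from compound 2 to compound 3 (within the scatter).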

Compound 3, half-maximal inhibitory concentration: 900 nM
Beside the measured number, compound 3's estimate is 1.1-fold (0.05 log units) above it, within the range that was stated.
By their numbers in this assay, from the lowest: compounds 3 and 2 (each within the scatter of the next); then compound 1.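

In this assay, within the data shown here, pyridin-4-yl in place of pyridin-3-yl on the shared core gives a 1.1-fold lower number from compound 2 to compound 3 (0.05 log units; within the scatter), the first measured step at this position. Within the scatter, this assay does not tell the two pyridine attachments apart, so the placement of the ring nitrogen does not register for this pair. Nothing available explains this result. The compounds shown leave open how pyridin-2-yl would read at this position, and whether a ring without nitrogen, such as a thiophene, or a pyridine carrying an amine would hold the same level.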